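From bromo to methyl on the aromatic ring

This account rests on a few compounds, and the source may have more. Where it says the series, first, only, none or still open, it means among the compounds named here.

In a functional assay (mast cells) for inhibition, with Rattus norvegicus as the target (on this read-out lower numbers stand for an effect already at smaller amounts and higher numbers for an effect only at larger amounts of compound), compound 1 (`CCOC(=O)c1cnc2n(c1=O)C(C)CC/C2=N\Nc1cccc(C(=O)O)c1`) gives 740000 nM and compound 2 (`CC1CCn2c(ncc(C(=O)O)c2=O)/C1=N/Nc1ccccc1`) gives 5400 nM while compound 3 (`CC1CC/C(=N\Nc2ccc(Br)cc2)c2ncc(C(=O)O)c(=O)n21`) stands lowest of the three at 2000 nM with both gaps beyond the scatter. Compound 4 (`Cc1ccc(N/N=C2\CCC(C)n3c2ncc(C(=O)O)c3=O)cc1`) carries methyl in place of bromo on an aromatic carbon, para to a large group (methyl in place of bromo on an aromatic carbon). For the measured compounds named here, no measured pair shows this change directly, so the only guide is the close placing of compound 3 at 2000 nM and compound 2 at 5400 nM in this assay as the two lowest numbers. A small upward step is expected (a 1.8-fold higher number from compound 3 to compound 4 (0.24 log units; within the scatter)) that stays within the scatter. For compound 4 the estimate is 3500 nM with an expected range from 1100 nM to 11000 nM in this read-out.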

Compound 4, half-maximal effective concentration: 280 nM
Compound 4: middle estimate off by 13-fold (1.10 log units), on the high side; the measured number lies below the stated range.
By their numbers in this assay, from the lowest: compound 4; then compound 3; then compound 2; then compound 1.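

In this assay, methyl in place of bromo on an aromatic carbon, para to a large group, gives a 7.1-fold lower number from compound 3 to compound 4 (0.85 log units; beyond the scatter), a step beyond the scatter. For the compounds shown here, the earlier compounds included no pair differing in one place, so this is the first sign that the aromatic substituent at this position alone can move the number. No measurement here explains why methyl gives the lower number. On these data alone, whether chloro, methoxy, or a longer chain such as ethyl would go lower still remains open.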